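Swapping Methyl for Chloro on the Aryl Ring

The source may report more compounds than this note shows. Statements on the series, on what has been measured and on what is new or still open speak of the compounds shown alone.

Compound 1 `COc1ncc(-c2ccc3c(c2)N(c2ccc(C)cc2)C(=O)CO3)cc1NS(=O)(=O)c1ccc(F)cc1`: in a functional assay on A549 cells (Homo sapiens) for antiproliferative activity, read by MTT assay, with a stated time of 72 h (on this read-out lower numbers stand for stronger inhibition and higher numbers for weaker inhibition), compound 1 gives 5870 nM.
Compound 2 `Cc1ccc(N2C(=O)COc3ccc(-c4cnc(Cl)c(NS(=O)(=O)c5ccc(F)cc5)c4)cc32)cc1`: in this assay compound 2 gives 30900 nM.
Compound 3 `O=C1COc2ccc(-c3cnc4ccccc4c3)cc2N1`: in this assay compound 3 reaches only a limit of the assay, > 40000 nM.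

Compound 1 holds the lowest of the two numbers; the nearest is a 5.3-fold higher number from compound 1 to compound 2 (0.72 log units; beyond the scatter), a step that puts chloro in place of methoxy on an aromatic carbon. The value of compound 3 is a limit, (the limit of > 40000 nM in this assay, at which 1 of the 3 values shown sits). Compound 4 `COc1ncc(-c2ccc3c(c2)N(c2ccc(Cl)cc2)C(=O)CO3)cc1NS(=O)(=O)c1ccc(F)cc1` differs from compound 1 in one place: chloro in place of methyl on an aromatic carbon. For the measured compounds named here, the measured step altered a different part of the shared core, so no measured step bears on this change directly. Compound 4 is therefore expected to stay close to compound 1, with the step of a 1.0-fold higher number from compound 1 to compound 4 (0.01 log units; within the scatter) lying within the scatter. The estimate for compound 4 is 6000 nM, between 2500 nM and 15000 nM.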

Compound 4, half-maximal inhibitory concentration: 8350 nM
Compound 4: middle estimate off by 1.4-fold (0.14 log units), on the low side, and the stated range covers the measured number.
By their numbers in this assay, from the lowest: compounds 1 and 4 (each within the scatter of the next); then compound 2. At a limit, above all of these: compound 3.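

In this assay, the change from 4-methylphenyl to 4-chlorophenyl gives a 1.4-fold higher number from compound 1 to compound 4 (0.15 log units; within the scatter) and so leaves the two compounds indistinguishable. For the compounds shown here, this is the first measured change on this ring, whereas the earlier step, a 5.3-fold higher number from compound 1 to compound 2 (0.72 log units; beyond the scatter), lay in a different part of the molecule and went beyond the scatter. Nothing measured here accounts for the result. Still open is whether the number would hold with an amine or a carboxylic acid in the same place on this ring, since methyl and chloro are the only groups shown there.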